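The source may hold more compounds than are shown below. What is called first, only, known or untested is meant among the compounds shown, and "the series" means these compounds.

In a functional assay on MOLT-4 cells (Homo sapiens) for inhibition, read by MTT assay, with a stated time of 72 h (on this read-out lower numbers stand for stronger inhibition and higher numbers for weaker inhibition), three compounds with a shared core have been measured so far. Compound 1 (`COc1cc(NC(C)CCCNC(=O)NNC(=O)Nc2ccc(F)cc2)c2ncccc2c1`) gives >= 250000 nM as its result, and this is a limit of the assay, not a number. Compound 2 (`COc1cc(NC(C)CCCNC(=O)NNC(=O)Nc2ccc(Cl)cc2)c2ncccc2c1`) gives 186000 nM as the higher of the two actual numbers, and compound 3 (`COc1cc(NC(C)CCCNC(=O)Nc2cccc(C(F)(F)F)c2)c2ncccc2c1`) gives 20000 nM as the lower one. Next comes compound 4 (`COc1cc(NC(C)CCCNC(=O)Nc2ccc(Cl)cc2)c2ncccc2c1`), which differs from compound 2 in one place, on an amide-type nitrogen: 4-chlorophenyl in place of ((4-chlorophenyl)carbamoyl)amino (4-chlorophenyl in place of ((4-chlorophenyl)carbamoyl)amino on an amide-type nitrogen). Two measured steps make a similar exchange, each putting 3-(trifluoromethyl)phenyl on that nitrogen. The closer one starts from compound 2 (a 9.3-fold lower number from compound 2 to compound 3 (0.97 log units; beyond the scatter)). The other starts from a limit and so gives only a floor (an at least 12-fold lower number from compound 1 to compound 3 (1.09 log units; beyond the scatter)). The swap of fluoro for chloro adds little to the picture (an at least 1.3-fold lower number from compound 1 to compound 2 (0.12 log units; that floor lies within the scatter)). Going by the values given here, a lower number of similar size is therefore expected, although compound 4 carries a different ring substituent from compound 3 and no measured step isolates that difference. The estimated change in this assay is a drop beyond the scatter (a 7.4-fold lower number from compound 2 to compound 4 (0.87 log units; beyond the scatter)). For compound 4 the estimated value is 25000 nM (expected range from 8000 nM to 80000 nM).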

Compound 4, half-maximal inhibitory concentration: 24000 nM
The estimate for compound 4 lay 1.0-fold (0.02 log units) above the measured number; measured number inside the range.
By their numbers in this assay, from the lowest: compounds 3 and 4 (each within the scatter of the next); then compound 2. At a limit, above all of these: compound 1.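

In this assay, compound 2 and compound 4 both carry a 4-chlorophenyl ring, so this change isolates the loss of the carbamoylamino link on the amide-type nitrogen, which compound 3 could not do with its different ring; the result is (a 7.8-fold lower number from compound 2 to compound 4 (0.89 log units; beyond the scatter)). The ring itself makes no clear difference in this set, since 4-chlorophenyl and 3-(trifluoromethyl)phenyl on that nitrogen cannot be told apart (a 1.2-fold higher number from compound 3 to compound 4 (0.08 log units; within the scatter)), and the shorter compounds 3 and 4 therefore sit together in the assay. The comparison with compound 1 points the same way (an at least 10-fold lower number from compound 1 to compound 4 (1.01 log units; beyond the scatter)), but compound 1 gives a limit and not a number, so this step is only a floor: the limit of >= 250000 nM in this assay, at which 1 of the 4 values shown sits.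

Still open, as far as these compounds go, is how far the ring on this nitrogen can be varied, for instance with an unsubstituted phenyl, a 4-fluorophenyl, a ring bearing an amine or a carboxylic acid, or a plain alkyl chain in place of the ring. The compounds shown also leave open whether a shorter or longer chain between the shared core and the urea would change the number.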